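Acetyl in place of cyclopropyloxy on the aromatic ring

This account rests on a few compounds, and the source may have more. Where it says the series, first, only, none or still open, it means among the compounds named here.

Measured so far:
compound 1 `CCc1ccccc1OC(C)C1=NCCN1` 282 nM
compound 2 `CC(Oc1ccccc1OC1CC1)C1=NCCN1` 1050 nM

Compound 2 gives the highest of the two numbers in an assay on CHO cells for displacement of a labelled ligand from Alpha-2B adrenergic receptor (Homo sapiens); a lower number here means a stronger inhibitor, a higher number a weaker inhibitor; its nearest neighbour is compound 1, which sits below it by the step of a 3.7-fold higher number from compound 1 to compound 2 (0.57 log units; beyond the scatter), a change that lies beyond the scatter. The series is therefore thin: one pair, one substituent exchange at one aromatic carbon.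

Compound 3 `CC(=O)c1ccccc1OC(C)C1=NCCN1` differs from compound 2 by acetyl in place of cyclopropyloxy on an aromatic carbon. Among the measured compounds shown here, no measured step covers this exchange directly. For the measured compounds named here, the only step that bears on it, a 3.7-fold higher number from compound 1 to compound 2 (0.57 log units; beyond the scatter), shows that a group without an oxygen at this aromatic carbon gave the lower number, and that the exchange of one substituent at this position moves the value by a modest amount. Acetyl, like ethyl, brings fewer heavy atoms than cyclopropyloxy and no ring, so the expectation is a modest move back toward the number of compound 1, with wide uncertainty in this assay.

Compound 3 is therefore expected to show a 2.1-fold lower number from compound 2 to compound 3 (0.32 log units; beyond the scatter), giving an estimated 500 nM with a range from 150 nM to 2000 nM.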

Compound 3, inhibition constant: 6170 nM
Estimate against measurement, compound 3: 12-fold (1.09 log units) below; the measured number lies above the stated range.
By their numbers in this assay, from the lowest: compound 1; then compound 2; then compound 3.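

In this assay, the choice of group at this aromatic carbon matters more than the first pair suggested, with acetyl in place of ethyl giving a large step (a 22-fold higher number from compound 1 to compound 3 (1.34 log units; beyond the scatter)). Acetyl in place of cyclopropyloxy (a 5.9-fold higher number from compound 2 to compound 3 (0.77 log units; beyond the scatter)) removes the ring and one heavy atom, yet the number moves further from that of compound 1, so the heavy-atom count of the group does not order these values, and both oxygen-bearing groups sit above ethyl, with no compound here going against that. No measurement offered here accounts for the order of ethyl, cyclopropyloxy and acetyl.

The compounds shown leave open whether the rise follows the oxygen itself or the particular groups, a question that methoxy or a longer chain such as propyl at this aromatic carbon would help to separate. They also leave open how an amine or a carboxylic acid would rank at this carbon, and whether the order of the three groups would hold on a core other than the one shared here.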